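A few compounds are considered here, and "the series" means these few. Any claim that something is new, unique, unknown or untested is made for them only; others in the source may bear on it.

Compound 1 `CCCCCCSc1n[nH]c(-n2[se]c3ccccc3c2=O)n1` carries hexyl on a sulfur whose other neighbour is an aromatic carbon of the shared core. In an ADME assay on L929 cells (Mus musculus) for antiproliferative activity, read by CCK-8 assay, with a stated time of 48 h (a higher number here means a weaker inhibitor, a lower number a stronger inhibitor), compound 1 gives 39300 nM; of the two numbers available it is one, and the other belongs to compound 2 `O=c1c2ccccc2[se]n1-c1nc(SCc2ccc(Cl)cc2)n[nH]1`, which in this assay gives 39500 nM, the pair lying within the scatter of each other. Compound 3 `O=c1c2ccccc2[se]n1-c1nc(SCc2ccc(F)cc2)n[nH]1` reaches only a limit in this assay, > 50000 nM, so no number is known for it (the limit of > 50000 nM in this assay, at which 1 of the 3 values shown sits). The steps recorded so far are a 1.0-fold higher number from compound 1 to compound 2 (0.00 log units; within the scatter), an at least 1.2-fold higher number from compound 1 to compound 3 (0.10 log units; that floor lies within the scatter) and an at least 1.2-fold higher number from compound 2 to compound 3 (0.10 log units; that floor lies within the scatter); none of them reaches beyond the scatter, and two end at the limit.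

Compound 4 `CC(C)Sc1n[nH]c(-n2[se]c3ccccc3c2=O)n1` differs from compound 1 by isopropyl in place of hexyl on a sulfur. For the measured compounds named here, no measured step shortens or lengthens the chain on that sulfur; the only step that alters this group, a 1.0-fold higher number from compound 1 to compound 2 (0.00 log units; within the scatter), lands within the scatter. With the three measured compounds sitting within the scatter of one another or at the limit, no step beyond the scatter is expected in this assay for compound 4 in either direction. Compound 4 is therefore expected to give 45000 nM in this assay, between 20000 nM and 100000 nM. The expected step is a 1.1-fold higher number from compound 1 to compound 4 (0.06 log units; within the scatter), within the scatter.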

Compound 4, half-maximal inhibitory concentration: 37100 nM
The estimate for compound 4 lay 1.2-fold (0.08 log units) above the measured number; the range from low to high includes it.
By their numbers in this assay, from the lowest: compounds 4, 1 and 2 (each within the scatter of the next). At a limit, above all of these: compound 3.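

In this assay, isopropyl in place of hexyl on the sulfur gives a 1.1-fold lower number from compound 1 to compound 4 (0.03 log units; within the scatter), so this position now has a direct comparison of two plain alkyl groups, and shortening the group from hexyl to isopropyl does not move the number beyond the scatter. Isopropyl in place of 4-chlorobenzyl on the same sulfur gives a 1.1-fold lower number from compound 2 to compound 4 (0.03 log units; within the scatter), so the three numbers now available, with hexyl, 4-chlorobenzyl and isopropyl on that sulfur, stay within the scatter across alkyl and benzyl groups alike. The 4-fluorobenzyl member remains a limit and not a number, so the step of an at least 1.3-fold lower number from compound 3 to compound 4 (0.12 log units; that floor lies within the scatter) is a floor only and its true size cannot be read: the limit of > 50000 nM in this assay, at which 1 of the 4 values shown sits.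

Still open, from the compounds shown here alone, is whether any group on this sulfur can move the number in this assay beyond the scatter, for instance a chain ending in an amine or a carboxylic acid. The shared core is also the same throughout, so the compounds shown say nothing about how a change there would read.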